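This account rests on a few compounds, and the source may have more. Where it says the series, first, only, none or still open, it means among the compounds named here.

Compound 1, `CN(C)c1ncnc2c1c(-c1ccsc1)cn2[C@@H]1O[C@H](CO)[C@@H](O)[C@H]1O`, gives > 15000 nM in a functional assay on HeLa S3 cells (Homo sapiens) for antiproliferative activity, read by XTT assay, with a stated time of 72 h; on this read-out lower numbers stand for stronger inhibition and higher numbers for weaker inhibition.
Compound 2, `C#Cc1cn([C@@H]2O[C@H](CO)[C@@H](O)[C@H]2O)c2ncnc(N(C)C)c12`, gives 810 nM in this assay.
Compound 3, `CN(C)c1ncnc2c1c(-c1cccs1)cn2[C@@H]1O[C@H](CO)[C@@H](O)[C@H]1O`, gives > 20000 nM in this assay.

Among the measured compounds shown here, of the three measured compounds, compound 2 is the only one with a number; the other two values are limits. The value of compound 1 is a limit of this assay, (the limit of > 15000 nM in this assay, at which 1 of the 3 values shown sits). The value of compound 3 is likewise a limit, (the limit of > 20000 nM in this assay, at which 1 of the 3 values shown sits). Compound 2 therefore stands alone as the one measured point in this assay, and both an at least 18-fold lower number from compound 1 to compound 2 (1.26 log units; beyond the scatter) and an at least 24-fold higher number from compound 2 to compound 3 (1.39 log units; beyond the scatter) are large, while a step that the two limits leave unreadable from compound 1 to compound 3 cannot be read from the two limits.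

Compound 4, `C#Cc1cn([C@@H]2O[C@H](CO)[C@@H](O)[C@H]2O)c2ncnc(SC)c12`, keeps the ethynyl group of compound 2 and differs only on the shared core: methylsulfanyl in place of dimethylamino on an aromatic carbon. For the measured compounds named here, none of the measured steps touches this position; all three concern the carbon that carries ethynyl or a thiophenyl group, so they give no direct guide to the size or the direction of this change. Going by the values given here, with no comparable step measured, only a modest step in this assay is expected, and compound 4 is estimated to give 2000 nM, within 400 nM to 10000 nM. That estimate means a step of a 2.5-fold higher number from compound 2 to compound 4 (0.39 log units; beyond the scatter) is expected.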

Compound 4, half-maximal inhibitory concentration: 110 nM
Compound 4: middle estimate off by 18-fold (1.26 log units), on the high side; measured number below the stated range.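

In this assay, with the ethynyl group held fixed, the aromatic carbon next to the ring nitrogen proves to be a second place where a single change moves the number: methylsulfanyl in place of dimethylamino gives a 7.4-fold lower number from compound 2 to compound 4 (0.87 log units; beyond the scatter) and so lies beyond the scatter. Among the compounds shown here, the earlier steps all concerned the carbon that carries ethynyl or a thiophenyl group, so this is the first sign that the read-out also responds to a change elsewhere on the shared core, and that the ethynyl group alone does not fix the number. The compounds shown offer nothing measured that accounts for this step.

With only dimethylamino and methylsulfanyl shown at this position, it remains open whether a longer chain on the sulfur such as ethylsulfanyl, a methoxy group or a primary amine would lower the number further or raise it again. Going by these compounds, it also remains open whether methylsulfanyl would bring any readable number to the thiophen-2-yl or thiophen-3-yl compounds, which so far stand only at limits of this assay.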